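Working notes on cytotoxicity in a small series

The source may report more compounds than this note shows. Statements on the series, on what has been measured and on what is new or still open speak of the compounds shown alone.

Three compounds share one core, all with an unmeasured fourth to follow. In an ADME assay on MOLT-3 cells (Homo sapiens) for cytotoxicity, with a stated time of 7 days (on this read-out lower numbers stand for higher toxicity in this test and higher numbers for lower toxicity in this test), compound 1 `CC(C)CSc1nc(N)nc2c1ncn2/C=C1/CC1(CO)CO` is recorded as "not determined" (no result reported). Compound 2 `Nc1nc(NCc2ccccc2)c2ncn(/C=C3/CC3(CO)CO)c2n1` returns only a limit of this assay, which is > 20000 nM. Compound 3 `Nc1nc(N2CCCC2)c2ncn(/C=C3/CC3(CO)CO)c2n1` carries no single number either; in this assay compound 3 is recorded as "not determined" (no result reported). So compound 3 stands among the two entries without a number, beside one entry that is a limit (the limit of > 20000 nM in this assay, at which 1 of the 3 values shown sits). Within the data shown here, no step between two measured compounds exists here, so nothing is known about how changes on the core move this read-out.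

Compound 4 `CCCOc1nc(N)nc2c1ncn2/C=C1/CC1(CO)CO` is the next compound for this assay. Its change from compound 3 is propoxy in place of pyrrolidin-1-yl on an aromatic carbon. Among the measured compounds shown here, with no measured step to lean on, no movement beyond the scatter of this assay is expected in either direction, and the one reported value, the limit for compound 2, suggests low toxicity across the set. Compound 4 is expected to give 30000 nM, within 10000 nM to 100000 nM, most likely reported as a limit.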

Compound 4, half-maximal cytotoxic concentration: > 20000 nM
Compound 4 gave a limit, no number; the forecaster's own chance of this, stated with the estimate: 70%; the middle value does not contradict the limit.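

Compound 2 and compound 4 are both recorded only as limits in this assay, so the step from one to the other cannot be read: the limit of > 20000 nM in this assay, at which 2 of the 4 values shown sit.

The compounds shown leave open whether any group at this place on the shared core gives a single cytotoxicity value.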